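Aryl ether amides: methyl in place of chloro

The source may report more compounds than this note shows. Statements on the series, on what has been measured and on what is new or still open speak of the compounds shown alone.

Measured so far in an assay on HEK293 cells for inhibition of N-acylethanolamine-hydrolyzing acid amidase (Rattus norvegicus), read by LC-MS, with a stated time of 30 min; on this read-out lower numbers stand for stronger inhibition and higher numbers for weaker inhibition:
compound 1 `COc1ccc(CCCCCC(=O)N2CCOC2=O)cc1` gives > 20000 nM, a limit of the assay and not a number.
compound 2 `O=C1OCCN1C(=O)c1ccc(Oc2ccccc2)cc1` gives 680 nM.
compound 3 `O=C1OCCN1C(=O)c1ccc(Oc2cccc(Cl)c2)cc1` gives 7740 nM.

Compound 3 stands highest of the two numbers recorded in this assay; the nearest is compound 2, separated by an 11-fold higher number from compound 2 to compound 3 (1.06 log units; beyond the scatter), a step beyond the scatter. Among the compounds with values here, compound 1 sits at the limit of > 20000 nM in this assay, at which 1 of the 3 values shown sits, and so supplies no step for comparison.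

Compound 4 `Cc1cccc(Oc2ccc(C(=O)N3CCOC3=O)cc2)c1` is still to be measured. It differs from compound 3 by methyl in place of chloro on an aromatic carbon.

Within the data shown here, only one measured step touches the same position: an 11-fold higher number from compound 2 to compound 3 (1.06 log units; beyond the scatter), which shows that chloro in place of hydrogen there raised the number by a large margin. Among the measured compounds shown here, no measured pair shows methyl at that position, so the series gives no direct read on methyl against chloro. The change is small in the structure, and the working expectation is that compound 4 stays near compound 3 rather than returning toward compound 2. The step expected from this change is a 1.5-fold lower number from compound 3 to compound 4 (0.19 log units; within the scatter), within the scatter. For compound 4 the estimate in this assay is 5000 nM, with a range from 1500 nM to 16000 nM.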

Compound 4, half-maximal inhibitory concentration: 5210 nM
Compound 4: middle estimate off by 1.0-fold (0.02 log units), on the low side, and the stated range covers the measured number.
By their numbers in this assay, from the lowest: compound 2; then compounds 4 and 3 (each within the scatter of the next). At a limit, above all of these: compound 1.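

In this assay, chloro and methyl on this aromatic carbon, meta to a large group, cannot be told apart (a 1.5-fold lower number from compound 3 to compound 4 (0.17 log units; within the scatter)), so the change from 3-chlorophenyl to 3-methylphenyl gives no real shift in the number. Methyl also leaves the number well away from the unsubstituted compound 2 (a 7.7-fold higher number from compound 2 to compound 4 (0.88 log units; beyond the scatter)), and chloro does the same (an 11-fold higher number from compound 2 to compound 3 (1.06 log units; beyond the scatter)), so the weaker inhibition at this position is not peculiar to chloro but holds for both groups tried, compounds 3 and 4. Nothing in hand bears on why the two groups read alike.

Still open, on these data alone, is whether a fluoro, an amine or a carboxylic acid on this same carbon would also move the number up as far, or would instead stay near compound 2. Equally open, as far as these compounds go, is whether chloro or methyl on another carbon of that ring would carry the same penalty, since both compounds with a substituent on this ring share one position.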